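The source may hold more compounds than are shown below. What is called first, only, known or untested is meant among the compounds shown, and "the series" means these compounds.

Compound 1 `Cc1cc2ccccc2nc1-c1cn(-c2ccc(F)cc2)nn1` and compound 2 `CCc1cc2ccccc2nc1-c1cn(-c2ccc(F)cc2)nn1` share a core and differ only by methyl in place of hydrogen on a saturated chain carbon bound to an aromatic carbon. In a functional assay on COLO 205 cells (Homo sapiens) for cytotoxicity, read by MTT assay, with a stated time of 24 h (a lower number here means a stronger inhibitor, a higher number a weaker inhibitor), compound 1 gives > 100 ug/mL, which is a limit of the assay rather than a number. In this assay compound 2 likewise gives > 100 ug/mL, again a limit and not a number. The step from compound 1 to compound 2 is therefore a step that the two limits leave unreadable from compound 1 to compound 2. Compound 3 `CCCc1cc2ccccc2nc1-c1cn(CCC(F)(F)C(F)(F)C(F)(F)C(F)(F)C(F)(F)C(F)(F)C(F)(F)C(F)(F)F)nn1` carries a different substituent pattern; the difference between the core of compound 3 and the core of compound 1 is not broken down here. In this assay compound 3 gives > 100 ug/mL, which is a limit of the assay. All three measured compounds thus sit at the limit of > 100 ug/mL in this assay, at which 3 of the 3 values shown sit.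

Compound 4 `CCCCc1cc2ccccc2nc1-c1cn(CCC(F)(F)C(F)(F)C(F)(F)C(F)(F)C(F)(F)C(F)(F)C(F)(F)C(F)(F)F)nn1` has not yet been measured. It differs from compound 3 by methyl in place of hydrogen on a saturated chain carbon, three bonds along the chain from an aromatic carbon. This is the same kind of change as that from compound 1 to compound 2, though the place is not identical: in the earlier pair the methyl enters on a saturated chain carbon bound to an aromatic carbon, whereas here it enters on a saturated chain carbon three bonds along the chain from an aromatic carbon. Given that compound 3 gives > 100 ug/mL and that the earlier step that the two limits leave unreadable from compound 1 to compound 2 was left unreadable, the expected step in this assay is a step that the limit leaves unreadable from compound 3 to compound 4. Compound 4 is therefore estimated to give 150 ug/mL, with a plausible range from 100 ug/mL to 300 ug/mL, and is expected most likely to be reported only as a limit.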

Compound 4, half-maximal inhibitory concentration: > 100 ug/mL
Compound 4 was reported as a limit; the forecaster's own chance of this, stated with the estimate: 85%; the middle value does not contradict the limit.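

In this assay compound 4 gives > 100 ug/mL, which is a limit of the assay and not a number. No size can be read for the step from compound 3 to compound 4, and all the compounds shown now stand at the same limit: the limit of > 100 ug/mL in this assay, at which 4 of the 4 values shown sit. The compounds shown leave open how large any of these chain steps is and which structural change, if any, would bring a readable value in this assay.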